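This account rests on a few compounds, and the source may have more. Where it says the series, first, only, none or still open, it means among the compounds named here.

Compound 2 `Cc1c(OCCCCOc2ccccc2C(=O)O)ccc(C(=O)CC2CCCC2)c1O`: 335 nM
Compound 1 `Cc1c(OCCCCOc2ccccc2C(=O)O)ccc(C(=O)CC2CCCC2)c1C`: 2580 nM
Compound 3 `CCC(=O)c1ccc(OCCCCOc2ccc(F)c(C(=O)O)c2)c(C)c1O`: 124 nM

In an assay on HEK293 cells for positive allosteric modulation of metabotropic glutamate receptor 2 (Rattus norvegicus), read by thallium flux, with a stated time of 2.5 min (a higher number here means that more compound is needed for the effect, a lower number that less compound is needed), compound 2 stands second highest of the three numbers, between compound 1 and compound 3. Compound 4 `Cc1cc(C(=O)O)ccc1OCCCCOc1ccc(C(=O)CC2CCCC2)c(O)c1C` differs from compound 2 in one place: 4-carboxy-2-methylphenyl in place of 2-carboxyphenyl on an oxygen on a saturated carbon. For the measured compounds named here, the only measured step, a 7.7-fold lower number from compound 1 to compound 2 (0.89 log units; beyond the scatter), concerns a hydroxy in place of a methyl on the shared core and does not bear on the carboxyphenyl end. Compound 3 carries a different carboxyphenyl but also differs from compound 2 elsewhere, so its value shows only that such variation can go with a low number. Going by the values given here, with no direct precedent, a modest step in this assay is expected, a 2.1-fold higher number from compound 2 to compound 4 (0.32 log units; beyond the scatter), most likely towards a higher number. Compound 4 is therefore estimated at 700 nM, within a range of 200 nM to 3000 nM.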

Compound 4, half-maximal effective concentration: 608 nM
Compound 4: middle estimate off by 1.2-fold (0.06 log units), on the high side, and the stated range covers the measured number.
By their numbers in this assay, from the lowest: compound 3; then compounds 2 and 4 (each within the scatter of the next); then compound 1.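

In this assay, putting 4-carboxy-2-methylphenyl in place of 2-carboxyphenyl gives a 1.8-fold higher number from compound 2 to compound 4 (0.26 log units; within the scatter), so this end of the molecule accepts the swap with no change that stands out from repeat scatter. The earlier step concerned only the shared core and could not show this. Nothing measured here explains the result. On these data alone, the methyl group and the new carboxy placement arrive together in compound 4, so their separate contributions remain unknown. Also open, as far as these compounds go, is how an amide or a tetrazole would fare at this end.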